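Swapping a Nitrophenyl for a Styryl Group

The source may report more compounds than this note shows. Statements on the series, on what has been measured and on what is new or still open speak of the compounds shown alone.

Three compounds have numbers in a functional assay on PC-3 cells (Homo sapiens) for cytotoxicity, read by sulforhodamine B assay, with a stated time of 48 h; a lower number here means a stronger inhibitor, a higher number a weaker inhibitor. Compound 1 `COc1ccc(C2CC(c3ccco3)=NN2C(C)=O)cc1` gives 15500 nM, compound 2 `O=CCN1N=C(c2ccc3ccccc3c2)CC1c1cccc([N+](=O)[O-])c1` gives 2980 nM, and compound 3 `COc1cc(C2CC(c3ccc4ccccc4c3)=NN2CC=O)cc(OC)c1OC` gives 570 nM. Compound 2 stands second highest of the three: compound 1 gives a higher number and compound 3 a lower one, both gaps beyond the scatter. Compound 4 `O=CCN1N=C(c2ccc3ccccc3c2)CC1/C=C/c1ccccc1` differs from compound 2 in one place: 2-phenylethenyl in place of 3-nitrophenyl on a saturated ring carbon. Within the data shown here, no single-point step has been measured between any two compounds here, so the effect of this change can only be guessed. The expectation is a small shift, a 1.3-fold higher number from compound 2 to compound 4 (0.13 log units; within the scatter), hardly beyond the scatter and if anything toward a weaker inhibitor. Compound 4 is therefore estimated at 4000 nM, with a range from 1200 nM to 13000 nM.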

Compound 4, half-maximal inhibitory concentration: 19100 nM
Beside the measured number, compound 4's estimate is 4.8-fold (0.68 log units) below it, and the stated range ends below it.
By their numbers in this assay, from the lowest: compound 3; then compound 2; then compounds 1 and 4 (each within the scatter of the next).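

Among these compounds, this is the first comparison that changes only one place, and it shows that the group on this saturated ring carbon matters. In this assay, 2-phenylethenyl in place of 3-nitrophenyl gives a 6.4-fold higher number from compound 2 to compound 4 (0.81 log units; beyond the scatter) and so a weaker inhibitor, even though both groups carry one six-membered aromatic ring of carbon only. No measurement shown here accounts for this step. Still open, going by these compounds, is how a plain phenyl group or a 3-aminophenyl group would read at this carbon. A saturated 2-phenylethyl chain there would show whether the double bond of the 2-phenylethenyl group matters.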